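A Methyl Group Added to the Saturated Ring

The source may report more compounds than this note shows. Statements on the series, on what has been measured and on what is new or still open speak of the compounds shown alone.

Measured so far:
compound 1 `O=C1CCCCC1C1CC(=O)N(c2ccccc2)C1=O` gives 78300 nM
compound 2 `O=C1CCCCC1C1CC(=O)N(Cc2ccccc2)C1=O` gives 36000 nM
compound 3 `O=C1CCOCC1C1CC(=O)N(c2ccccc2)C1=O` gives 26800 nM

All three were tested in an assay on cells (1-87 tumor cell line) for inhibition of Polyunsaturated fatty acid 5-lipoxygenase (Homo sapiens), with a stated time of 5 min; a higher number here means a weaker inhibitor, a lower number a stronger inhibitor. For the measured compounds named here, compound 2 holds the second highest of the three numbers: compound 3 sits slightly lower but within the scatter, so the two cannot be told apart, while compound 1 stands clearly higher, as seen in the only measured step, a 2.2-fold lower number from compound 1 to compound 2 (0.34 log units; beyond the scatter).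

Compound 4 `CC1CCC(=O)C(C2CC(=O)N(Cc3ccccc3)C2=O)C1` is not yet measured. It differs from compound 2 in one place: methyl in place of hydrogen on a saturated ring carbon. Going by the values given here, the one measured step concerns the group on the amide-type nitrogen, not the saturated ring, so it does not bear directly on this change. Among the compounds with values here, compounds 1 and 3 differ within that saturated ring, and there compound 1 gives 78300 nM while compound 3 gives 26800 nM; no step between them is computed. Within the data shown here, with a single small group entering on a ring carbon and no matching precedent, the expected step is one that stays within the scatter, a 1.1-fold lower number from compound 2 to compound 4 (0.05 log units; within the scatter). Compound 4 is therefore estimated at 32000 nM, with a range from 12000 nM to 80000 nM.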

Compound 4, half-maximal inhibitory concentration: 56200 nM
Estimate against measurement, compound 4: 1.8-fold (0.24 log units) below; the measured number falls inside the stated range.
By their numbers in this assay, from the lowest: compounds 3, 2, 4 and 1 (each within the scatter of the next, the first and the last beyond it).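

Placed on a saturated ring carbon, two ring bonds from the ring atom that bears a large group, the methyl gives in this assay a 1.6-fold higher number from compound 2 to compound 4 (0.19 log units; within the scatter) and so leaves compound 2 and compound 4 indistinguishable. For the compounds shown here, this is the first measured change on the carbon-only ring itself, and it shows that this position takes a methyl without a readable gain or loss in inhibition. Nothing available explains this result or says how the methyl is tolerated.

Still open, going by these compounds, is whether a larger or different group on this ring carbon, such as an ethyl, a hydroxyl or an amine, would move the number beyond the scatter. On these data alone, it is also open whether the same methyl would behave alike with phenyl rather than benzyl on the nitrogen, as in compound 1.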